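The source may report more compounds than this note shows. Statements on the series, on what has been measured and on what is new or still open speak of the compounds shown alone.

Measured compounds in a functional assay on CHO cells for positive allosteric modulation of metabotropic glutamate receptor 2 (Homo sapiens), read by scintillation counting and GTPgammaS binding, with a stated time of 30 min; a higher number here means a larger maximal response, a lower number a smaller maximal response:
Compound 1, `COc1ccc(-c2ccn(CCC(C)C)c(=O)c2C#N)cc1`: 160%
Compound 2, `COc1ccc(-c2ccn(CCC(C)C)c(=O)c2C#N)cc1Cl`: 200%
Compound 3, `COc1ccc(-c2ccn(CCC(C)C)c(=O)c2C#N)cc1OC`: 242%

Compound 2 stands second highest of the three numbers: the step of a number 40 percentage points higher from compound 1 to compound 2 (beyond the scatter) sets it apart from compound 1, and the step of a number 42 percentage points higher from compound 2 to compound 3 (beyond the scatter) places compound 3 further up. Compound 4, `CC(C)CCn1ccc(-c2ccc(NC3CCOCC3)c(Cl)c2)c(C#N)c1=O`, has not yet been measured in this assay. Its difference from compound 2 is (oxan-4-yl)amino in place of methoxy on an aromatic carbon. For the measured compounds named here, no measured step exchanges methoxy for an amino group, so none bears directly on this change. What the three compounds do show is that a group other than hydrogen at this site is accompanied by a larger maximal response: a number 82 percentage points higher from compound 1 to compound 3 (beyond the scatter) for methoxy and a number 40 percentage points higher from compound 1 to compound 2 (beyond the scatter) for chloro. Compound 4 keeps that site occupied, so a value near that of compound 2 seems plausible, but the direction of any shift is open. The step of a number 10 percentage points higher from compound 2 to compound 4 (within the scatter) is the expected outcome, with a broad band around it. Compound 4 is estimated at 210%, from 150% to 270%.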

Compound 4, largest response reached (Emax), in percent of the reference or control that the assay uses: 247%
Compound 4: middle estimate off by 37 percentage points, on the low side; measured number inside the range.
By their numbers in this assay, from the lowest: compound 1; then compound 2; then compounds 3 and 4 (each within the scatter of the next).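

For the compounds shown here, all earlier steps kept the methoxy group on this aromatic carbon, para to a large group, and varied only the site ortho to it, so compound 4 gives the first reading of a change at this carbon itself. In this assay, with the chloro group held constant, the carbon accepts a much larger group bearing a six-membered non-aromatic ring and a hydrogen-bond donor, with no loss of maximal response: a number 47 percentage points higher from compound 2 to compound 4 (beyond the scatter). Nothing available accounts for this rise.

The compounds shown do not separate the contributions of the amino nitrogen, the ring and the ring oxygen; a plain amino group, cyclohexylamino or (oxan-4-yl)oxy on this carbon would bear on that. Also open, as far as these compounds go, is whether the same exchange gives a similar step with methoxy or hydrogen in place of the neighbouring chloro group.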